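A methyl added to the ring core of compound 2

The source may hold more compounds than are shown below. What is called first, only, known or untested is meant among the compounds shown, and "the series" means these compounds.

Compound 2 `Cc1nc2c(OCc3ccccc3)cccn2c1N` gives 99% in a functional assay on the whole organism with Rattus norvegicus as the target, at a dose of 40 mg/kg by the intraperitoneal route (a higher number here means more inhibition at the dose given (going by the name of the read-out), a lower number less inhibition), the highest of the three numbers at hand. Compound 1 `Cc1ccn2c(C)c(C)nc2c1OCc1ccccc1` differs from compound 2 in several places. In this assay compound 1 gives 92%, within the scatter of compound 2. Within the data shown here, compound 3 `Cc1nc2c(OCc3ccccn3)cccn2c1N` gives 16%; the step of a number 83 percentage points lower from compound 2 to compound 3 (beyond the scatter) is the only single-point change measured, and it concerns the phenyl, not the ring carbon now in question. Compound 4 `Cc1ccn2c(N)c(C)nc2c1OCc1ccccc1` differs from compound 2 by methyl in place of hydrogen on an aromatic carbon. Among the measured compounds shown here, no measured step touches that ring carbon, while compound 1 and compound 2 both stand high. Compound 4 is therefore expected to give 95%, with a range from 80% to 100%. The expected step of a number 4 percentage points lower from compound 2 to compound 4 (within the scatter) stays within the scatter.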

Compound 4, a percentage reported as inhibition, in the whole organism at one dose (the size of the read-out at that dose, not a potency): 60%
Estimate against measurement, compound 4: 35 percentage points above; measured number below the stated range.
By their numbers in this assay, from the lowest: compound 3; then compound 4; then compounds 1 and 2 (each within the scatter of the next).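

Adding methyl on the aromatic carbon opposite the ring nitrogen is not a neutral change in this assay, with a number 39 percentage points lower from compound 2 to compound 4 (beyond the scatter) as the first measured step at this ring carbon. With that methyl present, amino in place of methyl on an aromatic carbon also counts, with a number 32 percentage points lower from compound 1 to compound 4 (beyond the scatter) in the same assay. Nothing at hand explains either step.

From the compounds shown here alone, whether an ethyl or a methoxy on this ring carbon would give a similar drop stays open. So does whether a chlorine there would.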